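A Benzyloxycarbonyl Swap Among Compounds Held at a Limit

A few compounds are considered here, and "the series" means these few. Any claim that something is new, unique, unknown or untested is made for them only; others in the source may bear on it.

Of the compounds shown here, three have been measured in a functional assay on L5178Y cells (Mus musculus) for inhibition, read by MTT assay, with a stated time of 24 h (on this read-out higher numbers stand for weaker inhibition and lower numbers for stronger inhibition), and none of them gives a number. Compound 1 (`Oc1ccc([C@@H]2C/C(=N\Nc3ccccc3)c3c(O)cc(O)cc3O2)cc1`) gives >= 11300 nM, which is a limit of the assay. Compound 2 (`O=C(Cc1c[nH]c2ccccc12)N/N=C1\C[C@@H](c2ccc(O)cc2)Oc2cc(O)cc(O)c21`) gives >= 11300 nM, again a limit. Compound 3 (`COc1cc(O)c2c(c1)O[C@H](c1ccc(O)cc1)C/C2=N\Nc1ccccc1`) gives >= 11300 nM, and this too is a limit. Compound 3 therefore has no readable position of its own, and the whole record comes down to the limit of >= 11300 nM in this assay, at which 3 of the 3 values shown sit.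

Compound 4 (`COc1cc(O)c2c(c1)O[C@H](c1ccc(O)cc1)C/C2=N\NC(=O)OCc1ccccc1`) has benzyloxycarbonyl in place of phenyl on an amine nitrogen of compound 3: benzyloxycarbonyl in place of phenyl on an amine nitrogen. Among the compounds with values here, the only measured step that bears on this is a step that the two limits leave unreadable from compound 1 to compound 3. That step is a different change, methyl in place of hydrogen on an oxygen on an aromatic ring, and it offers neither a size nor a direction to carry over. With nothing readable to build on, no step beyond the scatter is expected in this assay, and no direction is favoured. The expected change is a step that the limit leaves unreadable from compound 3 to compound 4. For compound 4 the estimated value is 12000 nM, with an expected range from 5000 nM to 30000 nM, and the result may well be only another limit.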

Compound 4, half-maximal inhibitory concentration: >= 11300 nM
Compound 4 was reported as a limit; the forecaster's own chance of this, stated with the estimate: 70%; the middle value does not contradict the limit.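

Compound 3 and compound 4 both stand at a limit, so the step between them, benzyloxycarbonyl in place of phenyl on an amine nitrogen, cannot be read, and the record stays at a single point: the limit of >= 11300 nM in this assay, at which 4 of the 4 values shown sit. The compounds shown leave open how strongly any of the four inhibits in this assay, and which change to the shared core, if any, would give a readable number.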